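Propargylamine aminoindanes: methoxy for trifluoromethyl on the arylthio side chain

The source may hold more compounds than are shown below. What is called first, only, known or untested is meant among the compounds shown, and "the series" means these compounds.

Measured compounds:
compound 1, `C#CCNC1CCc2c(SCCc3cccc(C(F)(F)F)c3)cccc21`, in an assay on isolated protein for inhibition of Amine oxidase [flavin-containing] B (Homo sapiens) (on this read-out higher numbers stand for weaker inhibition and lower numbers for stronger inhibition), gives 3720 nM;
compound 2, `C#CCNC1CCc2c(SCCc3cccc(OC)c3)cccc21`, in this assay gives 28700 nM;
compound 3, `C#CCNC1CCc2c(SCc3cccc(C(F)(F)F)c3)cccc21`, in this assay gives 4.7 nM.

Compound 1 and compound 2 share a core and differ in one place: methoxy in place of trifluoromethyl on an aromatic carbon. This change gives a 7.7-fold higher number from compound 1 to compound 2 (0.89 log units; beyond the scatter). Compound 3 carries the same trifluoromethyl-substituted aryl group on a shorter side chain; the difference between the core of compound 1 and the core of compound 3 is not broken down here. Compound 3 stands lowest of the three values, well beyond the scatter from both compound 1 and compound 2.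

Compound 4, `C#CCNC1CCc2c(SCc3cccc(OC)c3)cccc21`, is not yet measured. It differs from compound 3 as follows: methoxy in place of trifluoromethyl on an aromatic carbon. Among the compounds with values here, this is the same change as the one from compound 1 to compound 2, made on the core of compound 3. Within the data shown here, with only one prior instance of the change, the guide is a 7.7-fold higher number from compound 1 to compound 2 (0.89 log units; beyond the scatter). The step in this assay is therefore estimated to resemble it, that is about a 7.7-fold higher number from compound 3 to compound 4 (0.88 log units; beyond the scatter). On that basis compound 4 is expected to give roughly 36 nM in this assay, with a likely span from 12 nM to 110 nM.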

Compound 4, half-maximal inhibitory concentration: 3190 nM
For compound 4 the middle estimate is 89-fold (1.95 log units) below the measured one; measured number above the stated range.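

In this assay, methoxy in place of trifluoromethyl gives a higher number on both cores, but the size of the step does not carry from one core to the other: the same change on two cores in this assay, a 7.7-fold higher number (0.89 log units; beyond the scatter) from compound 1 to compound 2 and a 680-fold higher number (2.83 log units; beyond the scatter) from compound 3 to compound 4, 88-fold (1.94 log units) apart, beyond the scatter of two such steps

On the core of compound 3, the step is a 680-fold higher number from compound 3 to compound 4 (2.83 log units; beyond the scatter), so the step seen on the core of compound 1 is a poor guide to its size here. Direction held in both pairs, but two pairs set no rule for a further core and do not show what sets the size of the step.

Going by these compounds, it remains open whether a chlorine or a nitrile in place of trifluoromethyl would show the same gap between these two cores. On these data alone, it also remains open whether a longer chain would give a step closer to that on the core of compound 1 or to that on the core of compound 3.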